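Adding a Methoxy Group to a Weakly Cytotoxic Dienone

The compounds below may be only part of what the source reports. "The series", "measured", "known", "first", "only" and "open" are said of these compounds alone.

Of the compounds shown here, three of a shared core have been tested in a functional assay on Hep cells (Homo sapiens) for cytotoxicity, read by sulforhodamine B assay, with a stated time of 48 h; a lower number here means a stronger inhibitor, a higher number a weaker inhibitor. Compound 1 `COc1ccc(/C=C/C(=O)/C=C/C2=C(C)CCCC2(C)C)cc1OC` gives 72400 nM. For compound 2 `CC1=C(/C=C/C(=O)/C=C/c2ccoc2)C(C)(C)CCC1` the read-out is only a limit of the assay, > 100000 nM, and not a number. Compound 3 `CC1=C(/C=C/C(=O)/C=C/C=C/c2ccccc2)C(C)(C)CCC1` likewise reaches only a limit, > 100000 nM, so its potency is known only as a range. Among the three, compound 3 stands at the edge of the assay, as does compound 2, while compound 1 is the only one with a measured number; two of the three values sit at the limit of > 100000 nM in this assay, at which 2 of the 3 values shown sit.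

Compound 4 `COc1ccccc1/C=C/C=C/C(=O)/C=C/C1=C(C)CCCC1(C)C` differs from compound 3 in one place: methoxy in place of hydrogen on an aromatic carbon. Among the compounds with values here, no pair of measured compounds shows this exact change, so the size of the step can only be judged from the neighbours. Compound 1, which carries two methoxy groups on its aromatic ring, gives 72400 nM, still a high concentration. Compound 3 itself shows only a limit. The expected step, an at least 1.2-fold lower number from compound 3 to compound 4 (0.09 log units; that floor lies within the scatter), is small, within the usual scatter or at most a modest gain. Compound 4 is therefore estimated at 80000 nM, between 35000 nM and 180000 nM, with a real chance that this assay again reports only a limit.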

Compound 4, half-maximal inhibitory concentration: 65300 nM
The estimate for compound 4 lay 1.2-fold (0.09 log units) above the measured number; low and high end bracket the measured number.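

In this assay, within the data shown here, methoxy in place of hydrogen on an aromatic carbon, ortho to a large group, gives the first readable number on this side of the series, since compound 3 reads > 100000 nM, which is a limit of the assay and not a number. Compound 4 gives 65300 nM, which puts the change from phenyl to 2-methoxyphenyl at an at least 1.5-fold lower number from compound 3 to compound 4 (0.18 log units; that floor lies within the scatter). That figure is only a floor, so the real step could be larger, and its true size cannot be read because the starting point sits at the edge of the assay: the limit of > 100000 nM in this assay, at which 2 of the 4 values shown sit.

Still open is whether a single methoxy on this ring does anything that can be told apart from the scatter, and whether the same group elsewhere on the ring would give a similar number, as no pair shown tests that. The compounds shown also leave open what a hydroxyl, an amine or a carboxylic acid would do on this same carbon, and whether a longer chain such as ethoxy would move the number further.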